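The compounds below may be only part of what the source reports. "The series", "measured", "known", "first", "only" and "open" are said of these compounds alone.

Compound 2 `Nc1nc(Nc2cn[nH]c2)nc(-c2cccc(-n3ccc4cc(C5CC5)cc(F)c4c3=O)c2CO)n1` stands highest of the two numbers in an ADME assay on microsomes from liver (Homo sapiens) for metabolic stability, read by LC-MS, using NADPH, with a stated time of 30 min, tested at 1.5 uM; a higher number here means that more of the compound is left, a lower number that less of the compound is left: compound 2 gives 100%, whereas compound 1 `CC(C1CC1)n1cc(Nc2nc(N)nc(-c3cccc(-n4ccc5cc(C6CC6)cc(F)c5c4=O)c3CO)n2)cn1` gives 51%. Within the data shown here, the single step recorded, a number 49 percentage points higher from compound 1 to compound 2 (beyond the scatter), came with hydrogen in place of 1-cyclopropylethyl on an aromatic nitrogen. Compound 3 `Cn1cc(Nc2nc(N)nc(-c3cccc(-n4ccc5cc(C6CC6)cc(F)c5c4=O)c3CO)n2)cc1C#N` differs from compound 2 by 5-cyano-1-methyl-1H-pyrrol-3-yl in place of 1H-pyrazol-4-yl on a nitrogen on an aromatic ring. Among the measured compounds shown here, no measured step covers this exchange directly; the step from compound 1 to compound 2 bears on it only in that it was large and turned on the same kind of position, and the 5-cyano-1-methyl-1H-pyrrol-3-yl group entering compound 3 again brings no hydrogen-bond donor. A downward step beyond the scatter is therefore expected in this assay, though smaller than the one recorded. The expected step is a number 28 percentage points lower from compound 2 to compound 3 (beyond the scatter). Compound 3 is accordingly estimated at 72%, with a range from 48% to 95%.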

Compound 3, percent of the compound remaining in the Homo sapiens assay: 66%
Compound 3: middle estimate off by 6 percentage points, on the high side, and the stated range covers the measured number.
By their numbers in the Homo sapiens assay, from the lowest: compound 1; then compound 3; then compound 2.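

In the Homo sapiens assay, putting 5-cyano-1-methyl-1H-pyrrol-3-yl in place of 1H-pyrazol-4-yl on this nitrogen gave a number 34 percentage points lower from compound 2 to compound 3 (beyond the scatter), so a second, quite different group also stands below the 1H-pyrazol-4-yl of compound 2. The same group gave a number 15 percentage points higher from compound 1 to compound 3 (beyond the scatter), so among these three compounds the position yields three separate levels rather than two. The exchange also shows up in a physicochemical assay for solubility, read by LC-MS, measured as kinetic solubility, with a stated time of 1 h (on this read-out higher numbers stand for higher solubility and lower numbers for lower solubility), where compound 2 gives 12000 nM and compound 3 gives 670 nM and solubility drops: the measured solubility of compound 2, 12000 nM, and of compound 3, 670 nM, an 18-fold lower number (1.25 log units; beyond the scatter)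

Compound 3 alters the ring, the hydrogen on the aromatic nitrogen and the nitrile all at once, so the compounds shown leave open which of these changes goes with either drop. A 1-methyl-1H-pyrazol-4-yl group on this nitrogen would separate the loss of that hydrogen from the other two changes in both read-outs.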